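Aryl replacement on the shared core: aminophenyl for fluorophenyl

A few compounds are considered here, and "the series" means these few. Any claim that something is new, unique, unknown or untested is made for them only; others in the source may bear on it.

Compound 1 `COc1ccc(-c2nc3cccc(-c4cc(OC)c(OC)c(OC)c4)c3o2)cc1OC` gives 2800 nM in a functional assay on A549 cells (Homo sapiens) for antiproliferative activity, read by MTT assay, with a stated time of 48 h; a higher number here means a weaker inhibitor, a lower number a stronger inhibitor. Compound 2 `COc1cc(-c2cccc3nc(-c4cccc(F)c4)oc23)cc(OC)c1OC` gives 2600 nM in the same assay; the step of a 1.1-fold lower number from compound 1 to compound 2 (0.03 log units; within the scatter) is within the scatter, so compound 1 and compound 2 cannot be told apart on these two numbers. Compound 3 `COc1cc(-c2cccc3nc(-c4ccc(N)cc4)oc23)cc(OC)c1OC` differs from compound 2 only by 4-aminophenyl in place of 3-fluorophenyl on an aromatic carbon. For the measured compounds named here, the one measured step at this position, a 1.1-fold lower number from compound 1 to compound 2 (0.03 log units; within the scatter), exchanged aryl groups there without a change beyond the scatter, so no change beyond the scatter is expected for the step of no change at the digits printed from compound 2 to compound 3 (within the scatter). Compound 3 is therefore estimated at 2600 nM with a range of 1000 nM to 7000 nM.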

Compound 3, half-maximal inhibitory concentration: 720 nM
Estimate against measurement, compound 3: 3.6-fold (0.56 log units) above; the whole stated range lies above it.
By their numbers in this assay, from the lowest: compound 3; then compounds 2 and 1 (each within the scatter of the next).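

In this assay, this position does respond to the choice of aryl group: a 3.6-fold lower number from compound 2 to compound 3 (0.56 log units; beyond the scatter) and a 3.9-fold lower number from compound 1 to compound 3 (0.59 log units; beyond the scatter) both lie beyond the scatter, unlike the exchange between 3,4-dimethoxyphenyl and 3-fluorophenyl. Among these three compounds, only 4-aminophenyl stands apart, though the step from compound 2 to compound 3 changes both the substituent and its place on the ring. No supporting evidence is available to explain this difference.

Going by these compounds, whether the amine itself or its ring placement matters remains open. Comparing 3-aminophenyl and 4-fluorophenyl would separate those two changes, while 4-hydroxyphenyl would test another replacement for the amine.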